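This account rests on a few compounds, and the source may have more. Where it says the series, first, only, none or still open, it means among the compounds named here.

Working notes on the series.

Compound 1 `O=C(Nc1cccc(-n2cc(-c3ccncc3)c(-c3cc(O)cc(Cl)c3)n2)c1)Nc1ccc(Cl)c(Cl)c1`, compound 2 `COc1cc(Cl)cc(-c2nn(-c3cccc(NC(=O)Nc4cc(C(F)(F)F)cc(C(F)(F)F)c4)c3)cc2-c2ccncc2)c1` and compound 3 `COc1cc(Cl)cc(-c2nn(-c3cccc(NC(=O)Nc4ccc(Cl)c(Cl)c4)c3)cc2-c2ccncc2)c1` share one core and differ only in the substituents at its two outer ends. In a functional assay on SK-MEL-2 cells (Homo sapiens) for inhibition, read by sulforhodamine B assay, with a stated time of 48 h, tested at 0.1 uM (on this read-out higher numbers stand for a weaker effect at the one concentration tested and lower numbers for a stronger effect), compound 1 gives 96% and compound 2 gives 95%, while compound 3 gives 54%, the lowest of the three numbers. Among the measured compounds shown here, the only single-point step measured so far is a number 42 percentage points lower from compound 1 to compound 3 (beyond the scatter), a large step on this read-out. For the measured compounds named here, compound 2 and compound 3 differ at the far aryl group and no step is computed for that pair; their two values simply show compound 2 well above compound 3.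

Compound 4 `COc1cc(Cl)cc(-c2nn(-c3cccc(NC(=O)c4cccc(C(F)(F)F)c4)c3)cc2-c2ccncc2)c1` is the next member. Relative to compound 3 the change is 3-(trifluoromethyl)phenyl in place of (3,4-dichlorophenyl)amino on a carbonyl carbon. Going by the values given here, no measured step bears on this change: the only step seen concerns the methyl on the oxygen, not the carbonyl end. With the donor counted on the leaving group gone and a new aryl entering, the expectation is a step of a number 24 percentage points higher from compound 3 to compound 4 (beyond the scatter) in this assay, towards a weaker effect, with wide uncertainty. Compound 4 is thus estimated at 78%, within 50% to 100%.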

Compound 4, a percentage reported as activity, at one concentration (the size of the read-out at that concentration, not a potency): 95%
Compound 4: middle estimate off by 17 percentage points, on the low side; the measured number falls inside the stated range.
By their numbers in this assay, from the lowest: compound 3; then compounds 2, 4 and 1 (each within the scatter of the next).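

In this assay, 3-(trifluoromethyl)phenyl in place of (3,4-dichlorophenyl)amino on a carbonyl carbon gives a number 41 percentage points higher from compound 3 to compound 4 (beyond the scatter), so a large step also arises at this end of the molecule, not only at the methyl on the oxygen. With a number 42 percentage points lower from compound 1 to compound 3 (beyond the scatter) as the other measured step, each of the two single-place changes around compound 3 spans a large gap on this read-out. No measurement at hand accounts for the new step.

This change replaces the amino nitrogen and alters the aryl substitution together, so the compounds shown do not separate the contribution of either. On these data alone, a (3-(trifluoromethyl)phenyl)amino group on the same carbonyl carbon would address that, while the response to an aliphatic amine or a carboxylic acid at this end remains open.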